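From nitro to fluoro at the assay limit

The source may report more compounds than this note shows. Statements on the series, on what has been measured and on what is new or still open speak of the compounds shown alone.

Measured in an ADME assay on Raji cells (Homo sapiens) for cytotoxicity, with a stated time of 72 h (on this read-out lower numbers stand for an effect already at smaller amounts and higher numbers for an effect only at larger amounts of compound), each value a limit and not a number:
Compound 1 `CSc1ccc(NC(=O)Nc2cc(C)nc3ccccc23)cc1`: > 25000 nM
Compound 2 `CC(=O)c1ccc(NC(=O)Nc2cc(C)nc3ccccc23)cc1`: > 25000 nM
Compound 3 `Cc1cc(NC(=O)Nc2cccc([N+](=O)[O-])c2)c2ccccc2n1`: > 25000 nM

In this assay compound 3 has no number, only the limit > 25000 nM. The three compounds together stand at the limit of > 25000 nM in this assay, at which 3 of the 3 values shown sit. Compound 4 `Cc1cc(NC(=O)Nc2cccc(F)c2)c2ccccc2n1` carries fluoro in place of nitro on an aromatic carbon, meta to a large group: fluoro in place of nitro on an aromatic carbon. Going by the values given here, the only measured step, a step that the two limits leave unreadable from compound 1 to compound 2, is another exchange and offers no size to carry over. Among the compounds with values here, no step of definite size or direction is therefore expected, and the limit of compound 3 at > 25000 nM remains the sole anchor. The expected change is a number no higher from compound 3 to compound 4 (the limit leaves the size open). For compound 4 the estimated value is 25000 nM, with an expected range from 12000 nM to 50000 nM.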

Compound 4, half-maximal effective concentration: > 25000 nM
Compound 4: no number, only a limit; the forecaster's own chance of this, stated with the estimate: 85%; the middle value sits exactly at the limit.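

The step from compound 3 to compound 4 cannot be read in this assay, where compound 4 gives > 25000 nM, a limit and not a number. The compounds shown leave open what concentration, if any, would produce the half-maximal effect for any of them: the limit of > 25000 nM in this assay, at which 4 of the 4 values shown sit.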